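Swapping the sulfonyl aryl group: methoxy to fluoro

The source may hold more compounds than are shown below. What is called first, only, known or untested is meant among the compounds shown, and "the series" means these compounds.

Three compounds share one core and have been run in an ADME assay on microsomes from liver (Homo sapiens) for metabolic stability, tested at 2.5 uM; on this read-out higher numbers stand for fast clearance and lower numbers for slow clearance. Compound 1 `Cc1ccc(S(=O)(=O)c2cnc3c(F)cccc3c2-c2cccc(F)c2)cc1F` gives 3.92 mL/min, compound 2 `COc1ccc(-c2c(S(=O)(=O)c3ccc(F)cc3)cnc3c(F)cccc23)cc1` gives 2.41 mL/min, and compound 3 `COc1ccc(S(=O)(=O)c2cnc3c(F)cccc3c2-c2cccc(F)c2)cc1` gives 3.03 mL/min, which places compound 3 second highest of the three, within the scatter of both neighbours. Compound 4 `O=S(=O)(c1ccc(F)cc1)c1cnc2c(F)cccc2c1-c1cccc(F)c1` differs from compound 3 only on the sulfonyl aryl group: fluoro in place of methoxy on an aromatic carbon. Going by the values given here, the one measured step that alters this same aryl group, a 1.3-fold lower number from compound 1 to compound 3 (0.11 log units; within the scatter), stayed within the scatter, so no change beyond the scatter is expected in this assay; the step of a 1.0-fold lower number from compound 3 to compound 4 (0.00 log units; within the scatter) is the expected outcome. Compound 4 is therefore estimated at 3 mL/min, with a likely range from 1.7 mL/min to 5.3 mL/min.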

Compound 4, intrinsic clearance in a liver preparation (reported as CLH), per the amount of preparation that the assay uses: 1.56 mL/min
Compound 4: middle estimate off by 1.9-fold (0.28 log units), on the high side; the whole stated range lies above it.
By their numbers in this assay, from the lowest: compounds 4, 2, 3 and 1 (each within the scatter of the next, the first and the last beyond it).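

In this assay, changing the sulfonyl aryl group now gives a step beyond the scatter: 4-fluorophenyl in place of 3-fluoro-4-methylphenyl brings a 2.5-fold lower number from compound 1 to compound 4 (0.40 log units; beyond the scatter). Fluoro in place of methoxy brings a 1.9-fold lower number from compound 3 to compound 4 (0.29 log units; within the scatter), and the change of aryl group on the core brings a 1.5-fold lower number from compound 2 to compound 4 (0.19 log units; within the scatter); both stay within the scatter, so neither can be told from repeat-measurement noise. Nothing available here explains why these numbers differ.

Still open, from the compounds shown here alone, is how an amine or a carboxylic acid would read in this assay when placed on that same aromatic carbon, para to a large group.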